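Alpha-amino Substitution on the Amide Side Chain

This account rests on a few compounds, and the source may have more. Where it says the series, first, only, none or still open, it means among the compounds named here.

Measured compounds:
- compound 1 `CC1=NN(C(=O)CCl)C(c2cc(Br)ccc2O)C1` gives 8890 nM
- compound 2 `C=CCN(CC=C)CC(=O)N1N=C(C)CC1c1cc(Br)ccc1O` gives 3090 nM
- compound 3 `CCC(=O)N1N=C(c2cc3ccccc3oc2=O)CC1c1ccccc1` gives 4370 nM

These three compounds were tested in a functional assay on PC-3 cells (Homo sapiens) for cytotoxicity, read by MTT assay, with a stated time of 48 h; a lower number here means a stronger inhibitor, a higher number a weaker inhibitor. Compound 3 stands second highest of the three numbers: compound 2 sits close to it, within the scatter, while compound 1 is further off with a higher number, beyond the scatter. The unmeasured compound 4 `CC(C)CNCC(=O)N1N=C(c2cc3ccccc3oc2=O)CC1c1ccccc1` differs from compound 3 in one place: isobutylamino in place of methyl on a saturated chain carbon bound to a carbonyl carbon. Among the measured compounds shown here, only one measured step bears on this kind of change. Going from compound 1 to compound 2, an amine replaced the chloro group on the same saturated chain carbon bound to a carbonyl carbon, and the result was a 2.9-fold lower number from compound 1 to compound 2 (0.46 log units; beyond the scatter). That step rests on a different core and a different leaving group, so it is only a loose guide. Still, it is the only pointer, and on that basis a modest decrease in the number in this assay is expected for compound 4, with a 1.7-fold lower number from compound 3 to compound 4 (0.24 log units; within the scatter) as the estimated step. The value of compound 4 is estimated at 2500 nM, with a range from 1000 nM to 6000 nM.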

Compound 4, half-maximal inhibitory concentration: 1920 nM
Compound 4: middle estimate off by 1.3-fold (0.11 log units), on the high side, within the range that was stated.
By their numbers in this assay, from the lowest: compounds 4, 2 and 3 (each within the scatter of the next, the first and the last beyond it); then compound 1.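

In this assay, isobutylamino in place of methyl on a saturated chain carbon bound to a carbonyl carbon gives a 2.3-fold lower number from compound 3 to compound 4 (0.36 log units; beyond the scatter). An amine at this place thus goes with a lower number on a second core as well as on the core of compound 1, and here the group it replaces is a plain methyl rather than a chloro, so the earlier drop was not tied to losing chloro. Nothing measured here says why the number falls, so this remains an observation about structure and read-out alone.

On these data alone, whether the lower number follows the amine nitrogen or simply the longer chain stays open, and a pentyl chain in the same place would help to separate the two. Also open, as far as these compounds go, is how a different amine, such as dimethylamino, would compare with isobutylamino on the core of compound 3.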